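Replacing 2-(thiophen-2-yl)ethynyl in compound 2

The source may hold more compounds than are shown below. What is called first, only, known or untested is meant among the compounds shown, and "the series" means these compounds.

In a functional assay on Z-138 cells (Homo sapiens) for antiproliferative activity, with a stated time of 72 h (a higher number here means a weaker inhibitor, a lower number a stronger inhibitor), compound 1 (`CCCC#Cc1cc([C@@H]2O[C@H](CO)[C@@H](O)[C@H]2O)n2ncnc(N)c12`) gives 20 nM. Compound 2 (`Nc1ncnn2c([C@@H]3O[C@H](CO)[C@@H](O)[C@H]3O)cc(C#Cc3cccs3)c12`) gives 50100 nM, and compound 3 (`Nc1ncnn2c([C@@H]3O[C@H](CO)[C@@H](O)[C@H]3O)cc(C#Cc3ccccc3)c12`) gives 41400 nM. Compound 2 and compound 3 sit together, with a 1.2-fold lower number from compound 2 to compound 3 (0.08 log units; within the scatter), and both lie far from compound 1, as a 2500-fold higher number from compound 1 to compound 2 (3.40 log units; beyond the scatter) and a 2100-fold higher number from compound 1 to compound 3 (3.32 log units; beyond the scatter) show.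

Compound 4 (`Nc1ncnn2c([C@@H]3O[C@H](CO)[C@@H](O)[C@H]3O)cc(-c3ccc(F)cc3)c12`) keeps the shared core of compound 2 but carries 4-fluorophenyl in place of 2-(thiophen-2-yl)ethynyl on an aromatic carbon. The triple bond therefore leaves with the group. Within the data shown here, no measured step removes a triple bond, so none measures this change directly. The nearest guide is a 1.2-fold lower number from compound 2 to compound 3 (0.08 log units; within the scatter), where exchanging one aromatic ring for another on the triple bond stayed within the scatter. The large 2500-fold higher number from compound 1 to compound 2 (3.40 log units; beyond the scatter) involves propyl, which compound 4 does not carry, so a return towards compound 1 is not expected. In this assay, a modest move towards a lower number is expected, with considerable uncertainty. The estimated step is a 2.5-fold lower number from compound 2 to compound 4 (0.40 log units; beyond the scatter). For compound 4 the expected value is 20000 nM, within an estimated range of 2000 nM to 80000 nM.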

Compound 4, half-maximal inhibitory concentration: > 100000 nM
Compound 4: a limit, no number; the forecaster's own chance of this, stated with the estimate: 25%; middle value at least 5.0-fold (0.69 log units) away from the limit.
By their numbers in this assay, from the lowest: compound 1; then compounds 3 and 2 (each within the scatter of the next). At a limit, above all of these: compound 4.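

In this assay compound 4 stands at a limit of the assay, which is not a number: the limit of > 100000 nM in this assay, at which 1 of the 4 values shown sits.

Read as floors, the steps are an at least 1.9-fold higher number from compound 2 to compound 4 (0.30 log units; that floor lies within the scatter), an at least 2.4-fold higher number from compound 3 to compound 4 (0.38 log units; beyond the scatter) and an at least 5000-fold higher number from compound 1 to compound 4 (3.69 log units; beyond the scatter), so only the first leaves compound 4 unseparated from its partner. Taking away the triple bond together with the thiophene and attaching an aromatic ring directly to the aromatic carbon therefore brought no return towards compound 1, and all three compounds with an aromatic ring in this position, whether on a triple bond or not, lie far from it.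

As far as these compounds go, how far compound 4 lies beyond its limit stays open, and with it the true size of all three steps. Also open, from the compounds shown here alone, is whether the low number of compound 1 rests on the triple bond or on the propyl chain it carries, a question that a saturated pentyl chain on the same aromatic carbon, or a triple bond bearing an amine, would address.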